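One Inverted Stereocentre in a Growth Inhibition Series

The source may report more compounds than this note shows. Statements on the series, on what has been measured and on what is new or still open speak of the compounds shown alone.

The account covers two measured compounds and one not yet measured, all tested or to be tested in a functional assay on A498 cells (Homo sapiens) for inhibition; on this read-out higher numbers stand for weaker inhibition of growth and lower numbers for stronger inhibition of growth. Compound 1 `CC(=O)CC/C=C(\C)CCC1=C(C)CCCC1(C)C` carries an open chain ending in a ketone. In this assay compound 1 returns only a limit of the measurement, > 15000 nM. Compound 2 `CC1=C(CC/C(C)=C/CC[C@@]2(C)CC[C@@H]([C@H](C)C(=O)O)OO2)C(C)(C)CCC1` is the second measured compound. In this assay compound 2 likewise returns only a limit, > 100000 nM. Going by the values given here, both values shown are limits, one at the limit of > 100000 nM in this assay, at which 1 of the 2 values shown sits, and one at the limit of > 15000 nM in this assay, at which 1 of the 2 values shown sits, so compound 2 stands on no numbered scale at all, and no measured step between compounds exists.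

Compound 3 `CC1=C(CC/C(C)=C/CC[C@@]2(C)CC[C@H]([C@H](C)C(=O)O)OO2)C(C)(C)CCC1` differs from compound 2 only in configuration: the two compounds have the same atoms and bonds and differ only in configuration as drawn: 1 of 4 stereo elements differ; a stereocentre at a saturated ring carbon is drawn S in compound 2 and R in compound 3. With nothing measured to anchor a direction, the step from compound 2 to compound 3 is expected to be a number no higher from compound 2 to compound 3 (the limit leaves the size open), none beyond the scatter. Compound 3 is therefore estimated at 100000 nM, between 30000 nM and 300000 nM, most likely again only a limit.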

Compound 3, concentration for 50% growth inhibition: > 5000 nM
Compound 3: only a limit was reported; the forecaster's own chance of this, stated with the estimate: 85%; the middle value lies beyond the limit too.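

In this assay compound 3 returns only a limit, > 5000 nM. Going by these compounds alone, compound 2 also gave only a limit, so no step from compound 2 to compound 3 can be read. As far as these compounds go, whether the one differing stereocentre affects growth inhibition stays open.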